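Swapping Trifluoromethyl for Fluoro on Compound 2

The source may report more compounds than this note shows. Statements on the series, on what has been measured and on what is new or still open speak of the compounds shown alone.

Compound 1 `Nc1ccc(/C=C2\SC(=O)N(Cc3ccc(C(F)(F)F)cc3)C2=O)cc1` and compound 2 `C=C(Br)C(=O)Nc1ccc(/C=C2\SC(=O)N(Cc3ccc(C(F)(F)F)cc3)C2=O)cc1` share one core and differ in a single place. Among the compounds with values here, in a functional assay on FM3A cells (Mus musculus) for cytotoxicity, read by cell counting, with a stated time of 2 days (on this read-out lower numbers stand for stronger inhibition and higher numbers for weaker inhibition), compound 1 gives 134000 nM, while compound 2 gives 23000 nM; the change between them, a 5.8-fold lower number from compound 1 to compound 2 (0.77 log units; beyond the scatter), leaves compound 2 with the lower of the two numbers measured so far. Compound 3 `C=C(Br)C(=O)Nc1ccc(/C=C2\SC(=O)N(Cc3ccc(F)cc3)C2=O)cc1` keeps everything in compound 2 except (fluoro in place of trifluoromethyl on an aromatic carbon). Within the data shown here, no measured step touches this part of the molecule: the only step known altered a different place, so there is nothing to show what this swap does. With no direct guide, the expectation is a step of a 1.3-fold higher number from compound 2 to compound 3 (0.12 log units; within the scatter) that stays within the scatter of this assay, with no confident direction. Compound 3 is therefore estimated at 30000 nM in this assay, with a range from 10000 nM to 90000 nM.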

Compound 3, half-maximal inhibitory concentration: 4600 nM
Compound 3: middle estimate off by 6.5-fold (0.81 log units), on the high side, and the stated range ends above it.
By their numbers in this assay, from the lowest: compound 3; then compound 2; then compound 1.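

Within the data shown here, until now, the only measured step lay elsewhere in the molecule, so nothing was known about this aromatic carbon, para to a large group. In this assay, putting fluoro in place of trifluoromethyl here gives a 5.0-fold lower number from compound 2 to compound 3 (0.70 log units; beyond the scatter), which shows that the group at this position can shift the read-out and that, of these two groups, fluoro goes with the lower number. Nothing measured here explains the drop.

With only two groups compared at this carbon, the compounds shown leave open whether chloro, methoxy or plain hydrogen there would give a lower or a higher number. They also leave open whether the same swap would give a step of similar size on compound 1, which has a free amine instead of the (1-bromoethenyl)carbonyl group.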